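Halogen swaps on a dinitrophenoxy chalcone series

This account rests on a few compounds, and the source may have more. Where it says the series, first, only, none or still open, it means among the compounds named here.

Compound 1 `O=C(/C=C/c1cc(Br)cc(Br)c1Oc1c([N+](=O)[O-])cc(C(F)(F)F)cc1[N+](=O)[O-])c1ccc(Cl)cc1` carries two bromo groups on its core and gives 6.76 ug/mL in a functional assay on MCF7 cells (Homo sapiens) for antiproliferative activity, read by MTT assay, with a stated time of 48 h; a higher number here means a weaker inhibitor, a lower number a stronger inhibitor. Compound 2 `O=C(/C=C/c1cccc(Br)c1Oc1c([N+](=O)[O-])cc(C(F)(F)F)cc1[N+](=O)[O-])c1ccc(Cl)cc1` gives 4.74 ug/mL in this assay, and compound 3 `O=C(/C=C/c1cccc(Cl)c1Oc1c([N+](=O)[O-])cc(C(F)(F)F)cc1[N+](=O)[O-])c1ccc(Cl)cc1` gives 3.21 ug/mL in this assay. The step of a 1.4-fold lower number from compound 1 to compound 2 (0.15 log units; within the scatter) and the step of a 1.5-fold higher number from compound 3 to compound 2 (0.17 log units; within the scatter) are both small. The difference between the core of compound 1 and the core of compound 3 is not broken down here. Compound 4 `O=C(/C=C/c1cc(Br)cc(Br)c1Oc1c([N+](=O)[O-])cc(C(F)(F)F)cc1[N+](=O)[O-])c1ccc(Br)cc1` has not yet been measured in this assay. It differs from compound 1 by bromo in place of chloro on an aromatic carbon. The measured pair of compound 3 and compound 2 shows (bromo in place of chloro on an aromatic carbon); this is the same kind of change, not the same, since in that pair the bromo sits ortho to a large group and meta to a 2-((4-chlorophenyl)carbonyl)ethenyl group, whereas in compound 4 it sits para to a large group. Because a 1.5-fold higher number from compound 3 to compound 2 (0.17 log units; within the scatter) is a small step, compound 4 is expected to move by about a 1.2-fold higher number from compound 1 to compound 4 (0.07 log units; within the scatter) from compound 1. The estimate for compound 4 in this assay is 8 ug/mL, expected to fall between 4.5 ug/mL and 14 ug/mL.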

Compound 4, half-maximal inhibitory concentration: 2.87 ug/mL
For compound 4 the middle estimate is 2.8-fold (0.45 log units) above the measured one; the whole stated range lies above it.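

In this assay, bromo in place of chloro on the 4-chlorophenyl group gives a 2.4-fold lower number from compound 1 to compound 4 (0.37 log units; beyond the scatter). Within the data shown here, this change does not carry over from one core to the other with the same size or direction: the same change on two cores in this assay, a 1.5-fold higher number (0.17 log units; within the scatter) from compound 3 to compound 2 and a 2.4-fold lower number (0.37 log units; beyond the scatter) from compound 1 to compound 4, 3.5-fold (0.54 log units) apart, beyond the scatter of two such steps The comparison rests on only two steps, which also differ in where the bromo enters, and they do not show whether that place, the other bromo group on the core of compound 1, or both account for the gap, nor do they give a rule for any further core.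

The compounds shown carry only hydrogen, chloro or bromo at the places that vary, leaving open how the series responds to fluoro, a methoxy group or an amine there. They also leave open what happens when the nitro or trifluoromethyl groups shared by all four compounds are replaced, for instance by a nitrile.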